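Ethoxy to isopropoxy on compound 2

The source may report more compounds than this note shows. Statements on the series, on what has been measured and on what is new or still open speak of the compounds shown alone.

In a functional assay on thoracic aorta (Rattus norvegicus, strain Wistar), with a stated time of 15 min (a higher number here means that more compound is needed for the effect, a lower number that less compound is needed), compound 2 (`CCOc1ccc(Br)cc1C(C)NC(=O)N(C)S(=O)(=O)c1ccc(C)cc1`) gives 28600 nM and shares the low end of the numbers with compound 3 (`CCOc1ccc(Br)cc1C(C)NC(=O)N(C)S(=O)(=O)c1ccc(Cl)cc1`), which gives 55700 nM in the same test. Between those two, a 1.9-fold higher number from compound 2 to compound 3 (0.29 log units; within the scatter) stays within the scatter, for chloro in place of methyl on an aromatic carbon. Compound 1 (`Cc1ccc(S(=O)(=O)N(C)C(=O)NC(C)c2cc(Br)ccc2OCc2ccccc2)cc1`) gives 67100 nM and stands apart from compound 2.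

Compound 4 (`Cc1ccc(S(=O)(=O)N(C)C(=O)NC(C)c2cc(Br)ccc2OC(C)C)cc1`) has not been measured. Its difference from compound 2 is methyl in place of hydrogen on a saturated chain carbon bound to an oxygen on an aromatic ring and a saturated chain carbon and reads as ethoxy to isopropoxy.

The step that bears most directly is a 2.3-fold lower number from compound 1 to compound 2 (0.37 log units; beyond the scatter) as a modest change, with methyl in place of phenyl on a saturated chain carbon bound to an oxygen on an aromatic ring. It touches the same ether group, yet a whole phenyl moved the number only that far. The chloro step lies elsewhere and says little here. A single added methyl is therefore expected to give a small step, leaning slightly upward, and the data cannot fix its direction. The expected move is a 1.3-fold higher number from compound 2 to compound 4 (0.12 log units; within the scatter) and probably stays within the scatter. For compound 4 the estimated value is 38000 nM with an expected range from 18000 nM to 75000 nM in this assay as well.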

Compound 4, half-maximal effective concentration: 34700 nM
The estimate for compound 4 lay 1.1-fold (0.04 log units) above the measured number; the measured number falls inside the stated range.
By their numbers in this assay, from the lowest: compounds 2, 4, 3 and 1 (each within the scatter of the next, the first and the last beyond it).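

In this assay, for the compounds shown here, ethoxy to isopropoxy gives a 1.2-fold higher number from compound 2 to compound 4 (0.08 log units; within the scatter), so a methyl in place of hydrogen on this saturated chain carbon produces no step that can be told from repeat measurements. Isopropyl in place of benzyl on the same oxygen gives a 1.9-fold lower number from compound 1 to compound 4 (0.29 log units; within the scatter), so compound 4 cannot be separated from either compound 1 or compound 2, although the step between those two, a 2.3-fold lower number from compound 1 to compound 2 (0.37 log units; beyond the scatter), lies beyond the scatter; at this ether position, the ethoxy, isopropoxy and benzyl-bearing compounds therefore span a narrow range, and that one step is the only sign of a difference among them. No measured evidence accompanies these numbers that could explain them.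

On these data alone, all three groups on this oxygen are hydrocarbon groups, so the effect of a free hydroxyl, a methoxy or a chain ending in an amine at the same place remains open. Also open, as far as these compounds go, is whether the isopropoxy group would match the ethoxy group with chloro in place of methyl on the other aromatic ring, since the chloro step is known only for the ethoxy pair.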